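Swapping Isopropyl for 3-(tert-butoxycarbonyl)propyl

The compounds below may be only part of what the source reports. "The series", "measured", "known", "first", "only" and "open" are said of these compounds alone.

In a functional assay (strain AB) with Danio rerio as the target, read by microscopy, with a stated time of 1 h (on this read-out lower numbers stand for an effect already at smaller amounts and higher numbers for an effect only at larger amounts of compound), compound 1 (`NC(=O)c1c(NC(=O)Nc2ccc(Cl)cc2)sc2c1CCN(CC1CCCCC1)C2`) gives 1890 nM and compound 2 (`COCCCN1CCc2c(sc(NC(=O)Nc3ccc(Cl)cc3)c2C(N)=O)C1`) gives 2400 nM and compound 3 (`CC(C)CN1CCc2c(sc(NC(=O)Nc3ccc(Cl)cc3)c2C(N)=O)C1`) gives 4510 nM on the same read-out. Compound 3 is set apart from only one of the other two: a step of a 2.4-fold higher number from compound 1 to compound 3 (0.38 log units; beyond the scatter) is modest while a step of a 1.9-fold higher number from compound 2 to compound 3 (0.27 log units; within the scatter) shows no separation. Compound 4 (`CC(C)(C)OC(=O)CCCCN1CCc2c(sc(NC(=O)Nc3ccc(Cl)cc3)c2C(N)=O)C1`) has 3-(tert-butoxycarbonyl)propyl in place of isopropyl on a saturated chain carbon bound to an amine nitrogen in a ring. The three measured steps all change this same place, and the remaining one, a 1.3-fold higher number from compound 1 to compound 2 (0.10 log units; within the scatter) is no larger than the others. None of them involves a group like the entering one, so they bear on it only loosely. A step beyond the scatter is therefore not expected in this assay and any direction is tentative. The expected change is a 1.4-fold lower number from compound 3 to compound 4 (0.15 log units; within the scatter) and would leave the two compounds unresolved. For compound 4 the estimate is 3200 nM with an expected range from 1200 nM to 8500 nM in this assay.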

Compound 4, half-maximal effective concentration: 710 nM
Compound 4: the middle estimate sits 4.5-fold (0.65 log units) above what was measured; the whole stated range lies above it.
By their numbers in this assay, from the lowest: compound 4; then compounds 1, 2 and 3 (each within the scatter of the next, the first and the last beyond it).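

In this assay, 3-(tert-butoxycarbonyl)propyl on a saturated chain carbon bound to an amine nitrogen in a ring replaces isopropyl with a clear drop in the number (a 6.4-fold lower number from compound 3 to compound 4 (0.80 log units; beyond the scatter)), and it also stands apart from the other two groups (a 3.4-fold lower number from compound 2 to compound 4 (0.53 log units; beyond the scatter); a 2.7-fold lower number from compound 1 to compound 4 (0.43 log units; beyond the scatter)). The position therefore accepts this group of 10 heavy atoms, and the lowest number of the four comes from an open chain, so the ring of cyclohexyl is not needed for a low number here. No measurement shown gives a reason for this step.

The compounds shown leave open whether the low number follows the length of the chain or its tert-butoxycarbonyl end. A plain hexyl chain, or a free carboxylic acid or an amine at the end of the propyl chain, would separate the two.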